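Two Methoxy Groups on the Sulfonyl Aryl Ring

A few compounds are considered here, and "the series" means these few. Any claim that something is new, unique, unknown or untested is made for them only; others in the source may bear on it.

Measured so far:
compound 1, `CN(c1ccc2[nH]c(-c3n[nH]c4ccccc34)cc2n1)S(=O)(=O)c1ccccc1`: 3700 nM
compound 2, `COc1ccc(S(=O)(=O)N(C)c2ccc3[nH]c(-c4n[nH]c5ccccc45)cc3n2)cc1`: 4340 nM

Of the compounds shown here, two have been tested in a functional assay on HL-60 cells (Homo sapiens) for antiproliferative activity, read by MTT assay, with a stated time of 72 h; a higher number here means a weaker inhibitor, a lower number a stronger inhibitor. Compound 1 `CN(c1ccc2[nH]c(-c3n[nH]c4ccccc34)cc2n1)S(=O)(=O)c1ccccc1` gives 3700 nM in this assay, and compound 2 `COc1ccc(S(=O)(=O)N(C)c2ccc3[nH]c(-c4n[nH]c5ccccc45)cc3n2)cc1` gives 4340 nM. Among the measured compounds shown here, the one change between them, methoxy in place of hydrogen on an aromatic carbon, brought a 1.2-fold higher number from compound 1 to compound 2 (0.07 log units; within the scatter), so the two numbers lie within the scatter of each other and neither compound can be called the stronger inhibitor on these data.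

Compound 3 `COc1ccc(S(=O)(=O)N(C)c2ccc3[nH]c(-c4n[nH]c5ccccc45)cc3n2)cc1OC` carries the same kind of change one step further: methoxy in place of hydrogen on an aromatic carbon. For the measured compounds named here, only one measured step bears on it, the one from the unsubstituted to the monomethoxy ring, which gave a 1.2-fold higher number from compound 1 to compound 2 (0.07 log units; within the scatter). Since that first methoxy moved nothing beyond the scatter, no movement beyond the scatter is expected from a second methoxy either, and compound 3 is expected to sit near compound 2 in this assay. The estimate for compound 3 is 4500 nM, in a range from 2200 nM to 9500 nM, corresponding to an expected step of a 1.0-fold higher number from compound 2 to compound 3 (0.02 log units; within the scatter).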

Compound 3, half-maximal inhibitory concentration: 6320 nM
Compound 3: the middle estimate sits 1.4-fold (0.15 log units) below what was measured; measured number inside the range.
By their numbers in this assay, from the lowest: compounds 1, 2 and 3 (each within the scatter of the next).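

In this assay, the second methoxy, which turns 4-methoxyphenyl into 3,4-dimethoxyphenyl, gives a 1.5-fold higher number from compound 2 to compound 3 (0.16 log units; within the scatter) and so shows that methoxy in place of hydrogen on this aromatic carbon, ortho to a methoxy group and meta to a large group, brings no shift that can be told from the scatter. The comparison of the whole ring, 3,4-dimethoxyphenyl in place of phenyl on the sulfonyl sulfur, gives a 1.7-fold higher number from compound 1 to compound 3 (0.23 log units; within the scatter) and adds what the single methoxy could not show: even both methoxy groups together leave the number within the scatter of the unsubstituted ring. No evidence is available that speaks to the reason for these numbers.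

As far as these compounds go, every substituent on the sulfonyl aryl ring so far is a methoxy group, so it remains open whether an amine, a carboxylic acid or a longer alkoxy chain at this position would move the number beyond the scatter. The three compounds also say nothing about a change made outside the sulfonyl aryl ring, since they share the rest of their structure.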